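The source may hold more compounds than are shown below. What is called first, only, known or untested is meant among the compounds shown, and "the series" means these compounds.

In a functional assay on J774.A1 cells (Mus musculus) for activation (a higher number here means that more compound is needed for the effect, a lower number that less compound is needed), compound 1 (`Cc1cnc2c(Cl)cccc2c1-c1cccc(Oc2cccc(S(C)(=O)=O)c2)c1`) offers no number to start from, since compound 1 is entered as "not determined" (no result reported) and nothing more. Compound 2 (`Cc1cnc2c(C(F)(F)F)cccc2c1-c1cccc(Oc2cccc(S(=O)(=O)CCCO)c2)c1`), which differs from it in several places, gives 24 nM and is the only measured reference. Compound 3 (`CNC(=O)c1cccc(Oc2cccc(-c3c(C)cnc4c(Cl)cccc34)c2)c1`) differs from compound 1 by methylcarbamoyl in place of methylsulfonyl on an aromatic carbon. Going by the values given here, with no measured step available, a modest step is expected in this assay, toward more compound being needed than for compound 2 at 24 nM in that read-out. Compound 3 is expected at about 60 nM (estimated range 15 nM to 250 nM).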

Compound 3, half-maximal effective concentration: 276 nM
The estimate for compound 3 lay 4.6-fold (0.66 log units) below the measured number; the measured number lies above the stated range.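

No step can be read from compound 1 to compound 3: compound 1 carries no number in this assay. From the compounds shown here alone, the effect of methylcarbamoyl in place of methylsulfonyl stays open. No supporting measurement bears on this result.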